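The source may hold more compounds than are shown below. What is called first, only, known or untested is meant among the compounds shown, and "the series" means these compounds.

Measured in an ADME assay on S9 fraction from liver (Rattus norvegicus, strain Wistar) for metabolic stability, tested at 0.1 uM (on this read-out higher numbers stand for fast clearance and lower numbers for slow clearance), so far:
- compound 1 `CN(c1cc(OCc2cc(F)c(Oc3ccc(Cl)c(C(F)(F)F)c3)c(F)c2)nc(=O)n1C)C1CC1` | 123 mL/min/kg
- compound 2 `CCOC(=O)CN(C)c1cc(OCc2cc(F)c(Oc3ccc(Cl)c(C(F)(F)F)c3)c(F)c2)nc(=O)n1C` | 13.8 mL/min/kg

Of these two, compound 2 has the lower number at 13.8 mL/min/kg and compound 1 the higher. Compound 3 `Cn1c(N2CCCC2)cc(OCc2cc(F)c(Oc3ccc(Cl)c(C(F)(F)F)c3)c(F)c2)nc1=O` has not yet been measured. It carries pyrrolidin-1-yl in place of ((ethoxycarbonyl)methyl)(methyl)amino on an aromatic carbon. Among the compounds with values here, one measured step bears on this change, an 8.9-fold lower number from compound 1 to compound 2 (0.95 log units; beyond the scatter), where (ethoxycarbonyl)methyl replaced cyclopropyl on a nitrogen on an aromatic ring. Compound 3 loses that same (ethoxycarbonyl)methyl group, so the change should partly reverse the step. Within the data shown here, no measured compound carries pyrrolidin-1-yl, so the size remains uncertain. A somewhat smaller step toward a higher number is expected, namely a 5.4-fold higher number from compound 2 to compound 3 (0.74 log units; beyond the scatter), beyond the scatter. For compound 3 the estimated value is 75 mL/min/kg, with an expected range from 28 mL/min/kg to 200 mL/min/kg in this assay.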

Compound 3, clearance: 3.11 mL/min/kg
For compound 3 the middle estimate is 24-fold (1.38 log units) above the measured one, outside the stated range (below it).
By their numbers in this assay, from the lowest: compound 3; then compound 2; then compound 1.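

In this assay, the (ethoxycarbonyl)methyl group proves unnecessary for a low number at this aromatic carbon: replacing the whole ((ethoxycarbonyl)methyl)(methyl)amino group with pyrrolidin-1-yl gives a 4.4-fold lower number from compound 2 to compound 3 (0.65 log units; beyond the scatter) and leaves compound 3 lowest of the three. The larger contrast is between two amines without the ester, where pyrrolidin-1-yl in place of cyclopropyl(methyl)amino gives a 40-fold lower number from compound 1 to compound 3 (1.60 log units; beyond the scatter) in this same read-out, so the form of the amine at this position alone spans more than the step that introduced the ester. Nothing given here accounts for either step.

As far as these compounds go, it remains open whether piperidin-1-yl or morpholin-4-yl would read like pyrrolidin-1-yl, or whether this low number is particular to the five-membered ring. Also open, from the compounds shown here alone, is where a carboxylic acid in place of the ethyl ester would fall.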